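The source may hold more compounds than are shown below. What is called first, only, known or untested is meant among the compounds shown, and "the series" means these compounds.

Measured in a functional assay on SW-620 cells (Homo sapiens); a lower number here means a stronger inhibitor of growth, a higher number a weaker inhibitor of growth:
- compound 1 `O=S(=O)(/C=C/c1ccc(Cl)cc1)Cc1ccc(Nc2ncnc3ccccc23)cc1`: 77000 nM
- compound 2 `O=S(=O)(/C=C/c1ccc(Cl)cc1Cl)Cc1ccc(Nc2ncnc3ccccc23)cc1`: 14000 nM
- compound 3 `O=S(=O)(/C=C/c1ccc(Cl)cc1Cl)Cc1ccc(Nc2ncnc3cc(Cl)ccc23)cc1`: > 100000 nM

Compound 3 gives > 100000 nM, which is a limit of the assay and not a number. Compound 4 `O=S(=O)(/C=C/c1ccc(F)cc1F)Cc1ccc(Nc2ncnc3cc(Cl)ccc23)cc1` differs from it in one group: 2,4-difluorophenyl in place of 2,4-dichlorophenyl on a double-bonded chain carbon bound to a double-bonded chain carbon. This puts 2,4-difluorophenyl in place of 2,4-dichlorophenyl on a double-bonded chain carbon bound to a double-bonded chain carbon.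

Going by the values given here, two measured steps bear on this change. The first is a 5.5-fold lower number from compound 1 to compound 2 (0.74 log units; beyond the scatter), where a chloro replaced a hydrogen on the same aromatic ring that changes here. The second is an at least 7.1-fold higher number from compound 2 to compound 3 (0.85 log units; beyond the scatter), where a chloro replaced a hydrogen on the shared core, and that chloro remains in compound 4. Among the compounds with values here, no compound with fluoro has been measured, so neither step can be carried over directly. The core chloro stays, and the ring chloros that accompanied the lower number in the first step are removed, so no strong gain is expected in this assay. The expected change is small, with the number staying near the top of the measured range. The step expected is an at least 1.2-fold lower number from compound 3 to compound 4 (0.09 log units; that floor lies within the scatter). For compound 4 the estimated value is 80000 nM, with an expected range from 25000 nM to 200000 nM.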

Compound 4, concentration for 50% growth inhibition: > 100000 nM
Compound 4: no number, only a limit; the forecaster's own chance of this, stated with the estimate: 50%; middle value at least 1.2-fold (0.09 log units) from the limit.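

In this assay compound 4 gives > 100000 nM, which is a limit of the assay and not a number. Going by these compounds alone, no step from compound 3 to compound 4 can be read, since both compounds stop at the same point: the limit of > 100000 nM in this assay, at which 2 of the 4 values shown sit. The compounds shown leave open whether 2,4-difluorophenyl in place of 2,4-dichlorophenyl changes growth inhibition at all, and in which direction.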